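A few compounds are considered here, and "the series" means these few. Any claim that something is new, unique, unknown or untested is made for them only; others in the source may bear on it.

Compound 1 `CCCCCCCCCCCSC(=S)C1=C(Nc2ccc(Cl)cc2Cl)CC(C)(C)CC1=O` and compound 3 `CCCCCCCCCCCSC(=S)C1=C(Nc2ccc(Cl)cc2)CC(C)(C)CC1=O` share one core and differ by hydrogen in place of chloro on an aromatic carbon. In a functional assay on PBMC cells (Homo sapiens) for inhibition, read by ELISA, with a stated time of 18 h (a lower number here means a stronger inhibitor, a higher number a weaker inhibitor), compound 1 gives only a limit, > 20 ug/mL. Compound 3 likewise stops at the limit of > 20 ug/mL in this assay. The step that the two limits leave unreadable from compound 1 to compound 3 therefore has no readable size, because the limit of > 20 ug/mL in this assay, at which 3 of the 3 values shown sit, holds both ends of it. Compound 2 `CC(=O)OC[C@H]1O[C@@H](SC(=S)C2=C(Nc3ccc(Cl)cc3Cl)CC(C)(C)CC2=O)[C@H](OC(C)=O)[C@@H](OC(C)=O)[C@@H]1OC(C)=O` carries a different core; how its core differs from that of compound 1 is not broken down here. In this assay compound 2 also reaches only the limit, > 20 ug/mL. Compound 4 `CC(=O)OC[C@H]1O[C@@H](SC(=S)C2=C(Nc3ccc(Cl)cc3)CC(C)(C)CC2=O)[C@H](OC(C)=O)[C@@H](OC(C)=O)[C@@H]1OC(C)=O` differs from compound 2 by hydrogen in place of chloro on an aromatic carbon, the same change seen between compound 1 and compound 3. The step that the limit leaves unreadable from compound 2 to compound 4 is expected to stay unreadable, because the limit of > 20 ug/mL in this assay, at which 3 of the 3 values shown sit, gathers every value shown. Compound 4 is thus estimated at about 40 ug/mL in this assay, most likely reported again only as a limit.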

Compound 4, half-maximal inhibitory concentration: 3.5 ug/mL
Beside the measured number, compound 4's estimate is 11-fold (1.06 log units) above it; the measured number lies below the stated range.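

In this assay, hydrogen in place of chloro on an aromatic carbon gives an at least 5.7-fold lower number from compound 2 to compound 4 (0.75 log units; beyond the scatter), a step beyond the scatter for the change from 2,4-dichlorophenyl to 4-chlorophenyl on this core. The same change on the core of compound 1 cannot be read, so the data do not show whether the drop carries from one core to the other or holds only on the core of compound 2: the limit of > 20 ug/mL in this assay, at which 3 of the 4 values shown sit. The step is also only a bound, with compound 2 standing at a limit.

The compounds shown leave open whether the change would hold on any further core. They also leave open how compound 4 would respond to a methoxy group or an amine in place of its remaining chloro.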